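Removing a Methyl from the Benzamido Ring

The compounds below may be only part of what the source reports. "The series", "measured", "known", "first", "only" and "open" are said of these compounds alone.

Compound 2 `CCOC(=O)C1=C(C)NC(C)=C(C(=O)OCC)C1c1ccc(OCC(=O)NNC(=O)c2ccc(C)cc2)cc1` gives 16.7% in a functional assay on the whole organism (strain Wistar) for inhibition, with Rattus norvegicus as the target, read by paw edema, with stated times of 30 min and 0.5 h, at a dose of 20 mg/kg (on this read-out higher numbers stand for more inhibition at the one dose given (going by the name of the read-out) and lower numbers for less inhibition), the highest of the two numbers shown. Among the measured compounds shown here, compound 1 `CCOC(=O)C1=C(C)NC(C)=C(C(=O)OCC)C1c1ccc(OCC(=O)NCc2ccccc2)cc1` lies nearest with 8.33%, the only measured step being a number 8.4 percentage points higher from compound 1 to compound 2 (within the scatter). Compound 3 `CCOC(=O)C1=C(C)NC(C)=C(C(=O)OCC)C1c1ccc(OCC(=O)NNC(=O)c2ccccc2)cc1` differs from compound 2 by hydrogen in place of methyl on an aromatic carbon, a change on an aromatic carbon of a six-membered aromatic ring of carbon only. For the measured compounds named here, no measured step touches this ring, and the one step seen stayed within the scatter, so no step beyond the scatter is expected here. Compound 3 is therefore estimated at 15%, between 5% and 25%, an expected step of a number 1.7 percentage points lower from compound 2 to compound 3 (within the scatter).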

Compound 3, a percentage reported as inhibition, in the whole organism at one dose (the size of the read-out at that dose, not a potency): 9.1%
Compound 3: middle estimate off by 5.9 percentage points, on the high side, within the range that was stated.
By their numbers in this assay, from the lowest: compounds 1, 3 and 2 (each within the scatter of the next).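

With hydrogen in place of methyl on the aromatic carbon, this assay shows a number 7.6 percentage points lower from compound 2 to compound 3 (within the scatter) and so does not separate 4-methylphenyl from phenyl. Benzamido in place of benzyl on the amide-type nitrogen brings a number 0.8 percentage points higher from compound 1 to compound 3 (within the scatter) and likewise separates nothing, so neither place has yet shown a step beyond the scatter. No evidence bears on the reason for these numbers.

From the compounds shown here alone, whether a methoxy group, a chlorine atom or an amine on this aromatic carbon would give a step beyond the scatter remains open.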